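Antiproliferative series: the step from compound 2 to compound 3

The compounds below may be only part of what the source reports. "The series", "measured", "known", "first", "only" and "open" are said of these compounds alone.

Measured in a functional assay on DU-145 cells (Homo sapiens) for antiproliferative activity, read by MTT assay, with a stated time of 24 h; a lower number here means a stronger inhibitor, a higher number a weaker inhibitor:
compound 1, `COc1ccc(-c2noc(-c3ccc(Cl)cc3)n2)cc1OC1CCCC1`: 123000 nM
compound 2, `COc1ccc(-c2noc(C3CCCN3)n2)cc1OC1CCCC1`: 242000 nM

Compound 2 stands at the higher of the two numbers in this assay; its nearest neighbour is compound 1, and the step of a 2.0-fold higher number from compound 1 to compound 2 (0.29 log units; within the scatter) is the only one recorded, so the two compounds are not separated beyond the scatter.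

Compound 3, `COc1ccc(-c2noc(-c3ccncc3)n2)cc1OC1CCCC1`, has not yet been measured. It differs from compound 2 in one place: pyridin-4-yl in place of pyrrolidin-2-yl on an aromatic carbon. Among the compounds with values here, the only measured step that bears on this change is the one from compound 1 to compound 2, in which a six-membered aromatic ring was exchanged for pyrrolidin-2-yl without a shift beyond the scatter. Compound 3 restores a six-membered aromatic ring at the same place, so no more than a small step in this assay is expected, if any, toward the number of compound 1. For compound 3 the expected value is 160000 nM, with a range of 60000 nM to 400000 nM, which means a step of a 1.5-fold lower number from compound 2 to compound 3 (0.18 log units; within the scatter).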

Compound 3, half-maximal inhibitory concentration: > 1000000 nM
Compound 3 gave a limit, no number; the forecaster's own chance of this, stated with the estimate: 25%; middle value at least 6.2-fold (0.79 log units) from the limit.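

The reading for compound 3 in this assay is a limit and not a number: the limit of > 1000000 nM in this assay, at which 1 of the 3 values shown sits. With pyridin-4-yl on this aromatic carbon, the series shows its first moves beyond the scatter: the change from pyrrolidin-2-yl gives an at least 4.1-fold higher number from compound 2 to compound 3 (0.61 log units; beyond the scatter), and the change from 4-chlorophenyl gives an at least 8.1-fold higher number from compound 1 to compound 3 (0.91 log units; beyond the scatter). The position therefore does respond to the group it carries, and a six-membered aromatic ring alone does not keep the number of compound 1, whereas the earlier exchange of 4-chlorophenyl for pyrrolidin-2-yl stayed within the scatter.

On these data alone, the full size of both steps stays open, since one end of each is a limit. A plain phenyl group at this place would help separate the part played by the ring nitrogen of pyridin-4-yl from that of the chlorine of 4-chlorophenyl.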